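Swapping the acetyl ester for a nitrobenzoate on a macrocyclic core

A few compounds are considered here, and "the series" means these few. Any claim that something is new, unique, unknown or untested is made for them only; others in the source may bear on it.

Of the compounds shown here, two that share a large ring core have been tested so far. Compound 1, `CC(=O)OC/C1=C/C[C@](C)(CCC=C(C)C)/C=C/[C@@H](OC(=O)C=C(C)C)[C@](C)(O)/C=C/C1=O`, carries an acetoxy group on the ring. In a functional assay on A549 cells (Homo sapiens) for antiproliferative activity, read by MTT assay, with a stated time of 48 h (a higher number here means a weaker inhibitor, a lower number a stronger inhibitor), compound 1 gives 2950 nM. Compound 2, `C=C1/C=C/C(=O)/C(CO)=C\C[C@](C)(CCC=C(C)C)/C=C/[C@H]1OC(=O)C=C(C)C`, is a related ring in which that position carries a free hydroxymethyl group, and in this assay compound 2 gives 3090 nM. The two numbers sit within the usual scatter of each other, so neither compound can be called stronger than the other on this evidence.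

Compound 3, `CC(C)=CCC[C@]1(C)/C=C/[C@@H](OC(=O)C=C(C)C)[C@](C)(O)/C=C/C(=O)/C(COC(=O)c2ccc([N+](=O)[O-])cc2)=C\C1`, has not been measured. It differs from compound 1 in one place: 4-nitrophenyl in place of methyl on a carbonyl carbon. Going by the values given here, the data give no measured step for this kind of exchange, so the size and direction of its effect are unknown, and the expectation must stay wide. The step from compound 1 to compound 3 is expected to be a 1.2-fold lower number from compound 1 to compound 3 (0.07 log units; within the scatter), which may lie within the scatter. Compound 3 is therefore estimated to give 2500 nM in this assay, with a range from 700 nM to 9000 nM.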

Compound 3, half-maximal inhibitory concentration: 1310 nM
The estimate for compound 3 lay 1.9-fold (0.28 log units) above the measured number; low and high end bracket the measured number.
By their numbers in this assay, from the lowest: compound 3; then compounds 1 and 2 (each within the scatter of the next).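

In this assay, going by these compounds alone, the first measured change at this position is a 2.3-fold lower number from compound 1 to compound 3 (0.35 log units; beyond the scatter), a modest step but one beyond the scatter. It shows that this position on the shared core accepts much more than a methyl: a 4-nitrophenyl, with its six-membered aromatic ring, can sit on the same carbonyl carbon without loss of antiproliferative activity, and the number even falls somewhat. Nothing available here speaks to what lies behind this drop, so the step stands as an observation without an explanation.

From the compounds shown here alone, a single step cannot separate the contribution of the aromatic ring from that of the nitro group it carries, so it remains open whether a plain phenyl, or a phenyl bearing an amine or a carboxylic acid in place of the nitro group, would give a similar number. Going by these compounds, it is also open whether the ester link matters or only the size of what it holds, a question that an amide at this place, or a longer carbon chain in place of the 4-nitrophenyl, would begin to answer.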